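Swapping a Methylpiperazine for a Cyanopiperidine

A few compounds are considered here, and "the series" means these few. Any claim that something is new, unique, unknown or untested is made for them only; others in the source may bear on it.

Three compounds share one core and differ only in the group on an aromatic carbon. In a physicochemical assay for solubility, measured as kinetic solubility (a lower number here means a less soluble compound, a higher number a more soluble compound), compound 1 `O=C(Nc1ccnnc1)c1cc(N2CCNCC2)ccc1OCc1ccccc1` gives 98000 nM, compound 2 `O=C(Nc1ccnnc1)c1cc(N2CCC(CO)CC2)ccc1OCc1ccccc1` gives 323000 nM, and compound 3 `CN1CCN(c2ccc(OCc3ccccc3)c(C(=O)Nc3ccnnc3)c2)CC1` gives 228000 nM. Compound 3 thus stands second highest of the three: the step of a 2.3-fold higher number from compound 1 to compound 3 (0.37 log units; beyond the scatter) is beyond the scatter, while the step of a 1.4-fold lower number from compound 2 to compound 3 (0.15 log units; within the scatter) leaves compound 2 and compound 3 within the scatter of each other. The remaining step, a 3.3-fold higher number from compound 1 to compound 2 (0.52 log units; beyond the scatter), is the largest of the three.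

Compound 4 `N#CC1CCN(c2ccc(OCc3ccccc3)c(C(=O)Nc3ccnnc3)c2)CC1` differs from compound 3 in one place: 4-cyanopiperidin-1-yl in place of 4-methylpiperazin-1-yl on an aromatic carbon. The step that bears most directly on this change is a 1.4-fold lower number from compound 2 to compound 3 (0.15 log units; within the scatter), where one six-membered ring with a hydroxymethyl group was exchanged for one with a methyl on the ring nitrogen without moving beyond the scatter. The step of a 2.3-fold higher number from compound 1 to compound 3 (0.37 log units; beyond the scatter) shows that adding that methyl did give a modest rise. Compound 4 keeps neither the methylated ring nitrogen nor the hydroxymethyl group. A modest lower number is therefore expected for compound 4, a 1.8-fold lower number from compound 3 to compound 4 (0.24 log units; within the scatter), quite possibly still within the scatter. Compound 4 is estimated at 130000 nM, with a range from 50000 nM to 300000 nM.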

Compound 4, solubility: < 1000 nM
Compound 4: a limit, no number; the forecaster's own chance of this, stated with the estimate: 5%; middle value at least 130-fold (2.11 log units) from the limit.
By their numbers in this assay, from the lowest: compound 1; then compounds 3 and 2 (each within the scatter of the next). At a limit, below all of these: compound 4.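

In this assay compound 4 gives < 1000 nM, which is a limit of the assay and not a number: the limit of < 1000 nM in this assay, at which 1 of the 4 values shown sits. Among the earlier compounds, changing the group on this aromatic carbon gave only modest steps or none beyond the scatter, but this change goes much further, with an at least 220-fold lower number from compound 3 to compound 4 (2.35 log units; beyond the scatter) and an at least 98-fold lower number from compound 1 to compound 4 (1.99 log units; beyond the scatter). The closest comparison is a change on the saturated ring carbon alone, cyano in place of hydroxymethyl, which gives an at least 320-fold lower number from compound 2 to compound 4 (2.50 log units; beyond the scatter), so the piperidine ring as such does not go with the low read-out.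

The limit leaves the true size of these steps open. The compounds shown also leave open what an unsubstituted piperidin-1-yl, a 4-methylpiperidin-1-yl or a 4-aminopiperidin-1-yl would give here, and so whether the drop goes with the nitrile itself or with the loss of the hydroxymethyl group.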